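Swapping the Aryl Group on a Nitrogen-Rich Five-Membered Ring

This account rests on a few compounds, and the source may have more. Where it says the series, first, only, none or still open, it means among the compounds named here.

Compound 2 `O=C1O/C(=C\Cn2cc(-c3cc(F)cc(F)c3)nn2)C(OCc2ccccc2)=C1OCc1ccccc1` places a 3,5-difluorophenyl group on an aromatic carbon of a five-membered aromatic ring with three nitrogens, hanging from a shared core. In a functional assay on CFPAC-1 cells (Homo sapiens) for antiproliferative activity, read by MTT assay, with a stated time of 72 h (a lower number here means a stronger inhibitor, a higher number a weaker inhibitor), compound 2 is reported only as "not active" (no number reported), with no single number behind it. Its close relative compound 3 `O=C1O/C(=C\Cn2cc(-c3cc(C(F)(F)F)cc(C(F)(F)F)c3)nn2)C(OCc2ccccc2)=C1OCc1ccccc1` carries two trifluoromethyl groups instead of the two fluorines. In this assay compound 3 reaches only a limit of the assay, > 100000 nM, and no number. That limit is also the point described by the limit of > 100000 nM in this assay, at which 1 of the 3 values shown sits. A more distant relative, compound 1 `O=C1O[C@H]([C@@H](O)Cn2cc(-c3ccc(Br)cc3)nn2)C(OCc2ccccc2)=C1OCc1ccccc1`, differs in the core itself as well as in the aryl group; in this assay compound 1 gives 5830 nM. Compound 4 `COc1ccccc1-c1cn(C/C=C2\OC(=O)C(OCc3ccccc3)=C2OCc2ccccc2)nn1` arises from compound 2 by one exchange: 2-methoxyphenyl in place of 3,5-difluorophenyl on an aromatic carbon. No measured step of this kind exists among these compounds, so the expectation is a step of no size beyond the usual scatter, with compound 4 remaining weak like compound 2. The estimate for compound 4 in this assay is 60000 nM, expected to fall between 8000 nM and 300000 nM.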

Compound 4, half-maximal inhibitory concentration: > 100000 nM
Compound 4: a limit, no number; the forecaster's own chance of this, stated with the estimate: 60%; at least 1.6-fold (0.22 log units) between middle value and limit.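

In this assay compound 4 gives > 100000 nM, which is a limit of the assay and not a number. Going by these compounds alone, compound 2 is reported only as "not active", so no step between compound 2 and compound 4 can be read. The compounds shown leave open whether any aryl group on the core of compound 4 would give a measurable value in this assay.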